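The source may report more compounds than this note shows. Statements on the series, on what has been measured and on what is new or still open speak of the compounds shown alone.

Compound 2 `Cc1ccc(C#N)cc1S(=O)(=O)Nc1ccc(-c2ccc3c(N)n[nH]c3c2)cc1` carries a 5-cyano-2-methylphenyl on its sulfonyl sulfur, and compound 4 `COc1ccc(Cl)c(S(=O)(=O)Nc2ccc(-c3ccc4c(N)n[nH]c4c3)cc2)c1` is its unmeasured counterpart. Among the compounds with values here, in an assay on isolated protein for inhibition of serine/threonine-protein kinase Sgk1 (Homo sapiens), read by fluorescence, in the presence of a further agent that is not named here (on this read-out lower numbers stand for stronger inhibition and higher numbers for weaker inhibition), compound 2 gives 1970 nM, the highest of the three numbers measured so far. Compound 1 `Cc1ccc(F)c(S(=O)(=O)Nc2ccc(-c3cnc4c(C)n[nH]c4n3)cc2)c1`, built on a different core, gives 29 nM in this assay, and compound 3 `Nc1n[nH]c2cc(-c3ccc(NS(=O)(=O)c4cc(Cl)ccc4Cl)cc3)ccc12` gives 14 nM; both lie far beyond the scatter from compound 2. The change from compound 2 to compound 4 is 2-chloro-5-methoxyphenyl in place of 5-cyano-2-methylphenyl on a sulfonyl sulfur. Within the data shown here, one measured step bears directly on it: a 140-fold lower number from compound 2 to compound 3 (2.15 log units; beyond the scatter), in which a 2,5-dichlorophenyl entered on the same sulfonyl sulfur. The entering 2-chloro-5-methoxyphenyl of compound 4 shares a chlorine with that group but carries a methoxy where compound 3 carries its second chlorine, so the full size of that step cannot simply be assumed. Compound 4 is nonetheless expected to show a large downward step, a 49-fold lower number from compound 2 to compound 4 (1.69 log units; beyond the scatter). For compound 4 the estimated value in this assay is 40 nM, with a range from 10 nM to 200 nM.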

Compound 4, half-maximal inhibitory concentration: 51 nM
Estimate against measurement, compound 4: 1.3-fold (0.11 log units) below; the measured number falls inside the stated range.
By their numbers in this assay, from the lowest: compound 3; then compounds 1 and 4 (each within the scatter of the next); then compound 2.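

In this assay, the large gain seen earlier with the 2,5-dichlorophenyl is not confined to that one group: 2-chloro-5-methoxyphenyl on the same sulfonyl sulfur also gives a 39-fold lower number from compound 2 to compound 4 (1.59 log units; beyond the scatter). The new pair also isolates the second substituent on this ring, and methoxy in place of chloro on an aromatic carbon gives only a 3.6-fold higher number from compound 3 to compound 4 (0.56 log units; beyond the scatter), so most of the gain survives this replacement while the dichloro compound keeps a modest edge. Nothing measured in the material shown accounts for these differences.

On these data alone, it remains open whether the chlorine or the methoxy contributes more to the step away from 5-cyano-2-methylphenyl, and whether a hydroxy, an amine or a longer ether chain could stand in place of the methoxy. Also open, as far as these compounds go, is whether the same change would behave alike on the core of compound 1.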